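Notes on the acyl aryl change in the thiourea series

The source may report more compounds than this note shows. Statements on the series, on what has been measured and on what is new or still open speak of the compounds shown alone.

Compound 1 `NC(=O)c1c(NC(=O)c2ccccc2Cl)sc2c1CCN(C(=S)Nc1cc(C(F)(F)F)cc(C(F)(F)F)c1)C2` gives 15000 nM in a functional assay on MKN-74 cells (Homo sapiens) for antiproliferative activity, with a stated time of 24 h (a lower number here means a stronger inhibitor, a higher number a weaker inhibitor), the highest of the two numbers shown. Compound 3 `NC(=O)c1c(NC(=O)c2ccccc2Br)sc2c1CCN(C(=S)Nc1ccccc1Br)C2` gives 13700 nM in this assay, a gap to compound 1 that sits within the scatter. Compound 2 `NC(=O)c1c(NC(=O)c2ccccc2Br)sc2c1CCN(C(=S)Nc1ccccc1F)C2` reaches only the limit > 50000 nM in this assay. Among the measured compounds shown here, the single measured step, an at least 3.6-fold lower number from compound 2 to compound 3 (0.56 log units; beyond the scatter), concerns the aryl on the thiourea, not the acyl aryl, so it does not bear on the change considered here. Compound 4 `NC(=O)c1c(NC(=O)c2ccc(C(F)(F)F)cc2)sc2c1CCN(C(=S)Nc1cc(C(F)(F)F)cc(C(F)(F)F)c1)C2` differs from compound 1 by 4-(trifluoromethyl)phenyl in place of 2-chlorophenyl on a carbonyl carbon. For the measured compounds named here, no measured pair changes a group at that carbonyl carbon, so no direction beyond the scatter is expected. For compound 4 the expected step is no change at the digits printed from compound 1 to compound 4 (within the scatter). Compound 4 is estimated at 15000 nM, within 4000 nM to 50000 nM.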

Compound 4, half-maximal inhibitory concentration: 13800 nM
Compound 4: middle estimate off by 1.1-fold (0.04 log units), on the high side; the measured number falls inside the stated range.
By their numbers in this assay, from the lowest: compounds 3, 4 and 1 (each within the scatter of the next). At a limit, above all of these: compound 2.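

In this assay, the change at this carbonyl carbon now has a measured step, a 1.1-fold lower number from compound 1 to compound 4 (0.04 log units; within the scatter), so the two aryl groups cannot be told apart on the core of compound 1. The earlier step concerned only the thiourea aryl. Nothing shown bears on why this swap makes no difference beyond the scatter.

On these data alone, whether the same swap reads alike with the thiourea aryl of compound 3 stays open. So does the outcome with an amine, a carboxylic acid or a longer chain at this carbonyl carbon.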